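The source may hold more compounds than are shown below. What is called first, only, known or untested is meant among the compounds shown, and "the series" means these compounds.

Compound 2 is `Cc1ccc(Nc2nc(Cl)nc3c2ncn3Cc2ccc(/C=C/C(=O)Nc3ccccc3N)cc2)cc1`. In a functional assay on HCT-116 cells (Homo sapiens) for antiproliferative activity, read by CCK-8 assay, with a stated time of 72 h, tested at 2 uM (on this read-out higher numbers stand for a stronger effect at the one concentration tested and lower numbers for a weaker effect), compound 2 gives 0.27%. For the measured compounds named here, the only comparison partner measured so far is compound 1, `Cc1ccc(Nc2nc(Cl)nc3c2ncn3Cc2ccc(C(=O)Nc3ccccc3N)cc2)cc1`, which in this assay gives 76.3%. These two differ in one place, and the step of a number 76 percentage points lower from compound 1 to compound 2 (beyond the scatter) shows that lengthening the link to the amide wiped out nearly all of the effect. On the numbers shown, compound 2 therefore stands at the bottom: it is the lower of the two values, far beneath compound 1.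

Compound 3 is `Nc1ccccc1NC(=O)/C=C/c1ccc(Cn2cnc3c(Nc4ccccc4)nc(Cl)nc32)cc1`. It keeps the whole frame of compound 2 and differs from it by hydrogen in place of methyl on an aromatic carbon. Going by the values given here, no measured step covers this kind of change; the one step on record, a number 76 percentage points lower from compound 1 to compound 2 (beyond the scatter), alters a different part of the molecule and says nothing about trimming a methyl from the aryl amine. With compound 2 already near the floor of this assay, there is little room to fall further, and no evidence for a rise. The expected step of a number 4.7 percentage points higher from compound 2 to compound 3 (within the scatter) is therefore small, within the scatter. For compound 3 the estimate in this assay is 5%, with a likely range from 0% to 20%.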

Compound 3, a percentage reported as inhibition, at one concentration (the size of the read-out at that concentration, not a potency): 7.75%
The estimate for compound 3 lay 2.8 percentage points below the measured number; the range from low to high includes it.
By their numbers in this assay, from the lowest: compounds 2 and 3 (each within the scatter of the next); then compound 1.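

Replacing 4-methylphenyl with phenyl, which puts hydrogen in place of methyl on an aromatic carbon, gives a number 7.5 percentage points higher from compound 2 to compound 3 (within the scatter) in this assay. This shows that, with the ethenyl link in place, the methyl para to a large group can be swapped for hydrogen without a change that this read-out can separate from scatter, but the test is a limited one: both values lie so close to the bottom of the scale that a loss of effect would have little room to show. Nothing available explains why the two compounds give such similar numbers.

On these data alone, whether the same swap matters on the shorter link of compound 1, which gives 76.3%, remains open, and a value that high would leave room to see a loss as well as a gain. Also open, as far as these compounds go, is how methoxy, an amine or a longer chain such as propyl would behave at this place, and whether any of them could lift the ethenyl-linked compounds off the bottom of the scale.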